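From acetamido to fluoro on the shared core

This account rests on a few compounds, and the source may have more. Where it says the series, first, only, none or still open, it means among the compounds named here.

In an ADME assay on L6 cells (Rattus norvegicus) for cytotoxicity (on this read-out lower numbers stand for stronger inhibition and higher numbers for weaker inhibition), compound 1 `Cc1ccc(S(=O)(=O)N2c3ccccc3CCC2C)cc1` gives 4900 nM and compound 2 `COc1ccc(S(=O)(=O)N2c3ccccc3CCC2C)cc1` gives 5990 nM. Methoxy in place of methyl thus amounts to a 1.2-fold higher number from compound 1 to compound 2 (0.09 log units; within the scatter). Compound 3 `CC(=O)Nc1ccc(S(=O)(=O)N2c3ccccc3CCC2C)cc1` gives 52000 nM, the highest of the three numbers and so the weakest inhibition measured in this assay. Compound 4 `CC1CCc2ccccc2N1S(=O)(=O)c1ccc(F)cc1` has not yet been measured. It carries fluoro in place of acetamido on an aromatic carbon, para to a large group: fluoro in place of acetamido on an aromatic carbon. Within the data shown here, no measured compound carries fluoro, so the estimate rests on the two steps that introduce acetamido. These are an 11-fold higher number from compound 1 to compound 3 (1.03 log units; beyond the scatter) and an 8.7-fold higher number from compound 2 to compound 3 (0.94 log units; beyond the scatter). Read in reverse, they lead to the expectation of a similarly large fall in the number once acetamido leaves, returning it to the range of the two compounds without that group. The expected change is a 7.4-fold lower number from compound 3 to compound 4 (0.87 log units; beyond the scatter). Compound 4 is estimated at 7000 nM, with an expected range from 2500 nM to 20000 nM.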

Compound 4, half-maximal inhibitory concentration: 67600 nM
The estimate for compound 4 lay 9.7-fold (0.98 log units) below the measured number; the measured number lies above the stated range.
By their numbers in this assay, from the lowest: compounds 1 and 2 (each within the scatter of the next); then compounds 3 and 4 (each within the scatter of the next).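

At this position, para to a large group, fluoro in place of acetamido leaves the number in this assay where it was, with a 1.3-fold higher number from compound 3 to compound 4 (0.11 log units; within the scatter), so the high number of compound 3 is not specific to acetamido. Fluoro also stands well clear of the two smaller shifts seen earlier, with an 11-fold higher number from compound 2 to compound 4 (1.05 log units; beyond the scatter) and a 14-fold higher number from compound 1 to compound 4 (1.14 log units; beyond the scatter), which places methyl and methoxy on one side and fluoro and acetamido on the other, although fluoro has one heavy atom and acetamido four. Nothing shown here accounts for this split.

On these data alone, whether an amine, a carboxylic acid or chloro at this position would fall with methyl and methoxy or with fluoro and acetamido remains open. As far as these compounds go, each group is also seen at this one position only, so how fluoro behaves elsewhere on the ring is unknown.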